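The source may hold more compounds than are shown below. What is called first, only, known or untested is meant among the compounds shown, and "the series" means these compounds.

Measured so far:
- Compound 1, `O=C(O)c1cc(-c2cccc(COc3ccc4c(=O)n(C5CCC5)sc4c3)c2)ccc1Cl`, in an assay on HEK293 cells for positive allosteric modulation of metabotropic glutamate receptor 2 (Rattus norvegicus), read by thallium flux (on this read-out higher numbers stand for larger maximal responses and lower numbers for smaller maximal responses), gives 83%.
- Compound 2, `O=C1c2ccc(OCc3cccc(-c4ccc(C(F)(F)F)cc4F)c3)cc2CN1C1CCCC1`, in this assay has "not determined" (no result reported), so no result is reported for it.
- Compound 3, `O=C(O)c1cc(-c2cccc(COc3ccc4c(=O)n(C5CCCC5)sc4c3)c2)ccc1F`, gives 83.4% in this assay.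

Compound 2 therefore stands nowhere on the numbers shown: it carries a 2-fluoro-4-(trifluoromethyl)phenyl group and a cyclopentyl on its core, but no maximal response was reported for it. Compounds 1 and 3, which both carry a carboxylic acid on their outer ring, give values that lie within the usual scatter of each other, so no order between them can be claimed.

Compound 4, `O=C(O)c1cc(F)cc(-c2cccc(COc3ccc4c(c3)CN(C3CCCC3)C4=O)c2)c1`, differs from compound 2 in one place: 3-carboxy-5-fluorophenyl in place of 2-fluoro-4-(trifluoromethyl)phenyl on an aromatic carbon. The outer ring of compound 4 thus carries a carboxylic acid and a fluorine, a pattern that compounds 1 and 3 share in spirit, although those two sit on a different core. Among the measured compounds shown here, no step between measured compounds involves compound 4, and compound 2 itself has no number, so no direction of change can be read from the data; the expectation rests only on compounds 1 and 3.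

Given that compound 1 gives 83% and compound 3 gives 83.4%, compound 4 is estimated to reach 80%, with an expected range from 60% to 100%.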

Compound 4, largest response reached (reported as percent of maximum), in percent of the reference or control that the assay uses: 80.8%
Beside the measured number, compound 4's estimate is 0.8 percentage points below it, and the stated range covers the measured number.
By their numbers in this assay, from the lowest: compounds 4, 1 and 3 (each within the scatter of the next).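

No step can be read from this result: compound 2, which differs from compound 4 in one place, has no number in this assay, and compound 4, at 80.8%, differs from compounds 1 and 3 in more than one place. The compounds shown leave open how replacing 2-fluoro-4-(trifluoromethyl)phenyl with 3-carboxy-5-fluorophenyl changes the maximal response. No evidence here bears on this result.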